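A few compounds are considered here, and "the series" means these few. Any claim that something is new, unique, unknown or untested is made for them only; others in the source may bear on it.

Compound 2 `Cc1cccc(-n2cc(-c3cccc(NS(=O)(=O)c4c[nH]c(=O)[nH]c4=O)c3)nn2)c1` stands at the lower of the two numbers measured in an ADME assay on GES1 cells (Homo sapiens) for cytotoxicity, read by MTT assay, with a stated time of 24 h (on this read-out higher numbers stand for lower toxicity in this test and lower numbers for higher toxicity in this test), where compound 2 gives 18500 nM. Compound 1 `O=c1[nH]cc(S(=O)(=O)Nc2ccccc2-c2cn(-c3ccc(Cl)cc3)nn2)c(=O)[nH]1` is its nearest neighbour, and in this assay compound 1 gives 26700 nM, a gap that lies within the scatter, so the two cannot be ordered. Compound 3 `O=c1[nH]cc(S(=O)(=O)Nc2cccc(-c3cn(-c4cccc(Cl)c4)nn3)c2)c(=O)[nH]1` carries chloro in place of methyl on an aromatic carbon. Within the data shown here, no measured pair shows this exchange, so nothing larger than the scatter is expected from compound 2 to compound 3 in this assay, in either direction. Compound 3 is therefore estimated at 20000 nM, with a range from 8000 nM to 50000 nM, the expected step being a 1.1-fold higher number from compound 2 to compound 3 (0.03 log units; within the scatter).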

Compound 3, half-maximal cytotoxic concentration: 26200 nM
The estimate for compound 3 lay 1.3-fold (0.12 log units) below the measured number; low and high end bracket the measured number.
By their numbers in this assay, from the lowest: compounds 2, 3 and 1 (each within the scatter of the next).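

In this assay, among these compounds, the exchange of methyl for chloro on this aromatic carbon, meta to a large group, gives the first step between compounds that differ in one place (a 1.4-fold higher number from compound 2 to compound 3 (0.15 log units; within the scatter)). The 3-methylphenyl and 3-chlorophenyl compounds therefore cannot be told apart on this read-out. No supporting measurement bears on this result. From the compounds shown here alone, whether an amine or a carboxylic acid at this place would shift the number beyond the scatter remains open. So does whether the same exchange would behave alike elsewhere on the shared core.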